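Toward an Ethoxymethyl Analogue of an Inactive Compound

The source may report more compounds than this note shows. Statements on the series, on what has been measured and on what is new or still open speak of the compounds shown alone.

Measured compounds in an assay on HEK293 cells for agonist activity at putative P2Y purinoceptor 10 (Mus musculus), with a stated time of 1 h; on this read-out higher numbers stand for larger maximal responses and lower numbers for smaller maximal responses:
compound 1, `N[C@@H](COP(=O)(O)OCCOC(=O)CCc1ccccc1OCc1cccc(Oc2ccccc2)c1)C(=O)O`, gives 20.8%
compound 2, `C[C@H](COC(=O)CCc1ccccc1OCc1cccc(Oc2ccccc2)c1)OP(=O)(O)OC[C@H](N)C(=O)O`, gives 13.2%
compound 3, `COC[C@H](COC(=O)CCc1ccccc1OCc1cccc(Oc2ccccc2)c1)OP(=O)(O)OC[C@H](N)C(=O)O`, gives "not active" (no number reported)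

Compound 3 stands without a number: in this assay it is reported only as not active, so it carries no value to compare against the others. Compound 4, `CCOC[C@H](COC(=O)CCc1ccccc1OCc1cccc(Oc2ccccc2)c1)OP(=O)(O)OC[C@H](N)C(=O)O`, differs from compound 3 by methyl in place of hydrogen on a saturated chain carbon bound to an oxygen on a saturated carbon.

Within the data shown here, the only measured step of a comparable kind is a number 7.6 percentage points lower from compound 1 to compound 2 (within the scatter), where a methyl replaced a hydrogen on a saturated chain carbon one bond closer to the oxygen on an unsaturated carbon. That step did not move the response beyond the scatter. Among the measured compounds shown here, compound 2 still gives 13.2%, whereas compound 3 gives no number at all, so the change from methyl to methoxymethyl on that carbon coincides with the loss of a measurable response, though no step is reported for that pair.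

Given that compound 3 shows no measurable response, and that the single related step stayed within the scatter, compound 4 is expected to show little or no response in this assay, estimated at 6% with a range from 0% to 18%.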

Compound 4, largest response reached (Emax), in percent of the reference or control that the assay uses: "not active" (no number reported)
Compound 4: no number reported, and the estimate cannot be compared.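

In this assay compound 3 and compound 4 are both reported only as not active, without a number, so no step can be read between them. The compounds shown leave open how far methoxymethyl and ethoxymethyl differ in this read-out, if at all. No evidence bearing on this result is available.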